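The compounds below may be only part of what the source reports. "The series", "measured", "known", "first", "only" and "open" are said of these compounds alone.

In a functional assay on HepG2 cells (Homo sapiens) for cytotoxicity, read by MTT assay, with a stated time of 48 h (on this read-out higher numbers stand for weaker inhibition and lower numbers for stronger inhibition), compound 1 `CCOC(=O)/C=C/c1ccc2c(c1)C(=O)C(=O)N2Cc1ccc(OC)cc1` gives 90 nM. Compound 2 `COC(=O)/C=C/c1ccc2c(c1)C(=O)C(=O)N2Cc1ccc2ccccc2c1` gives 90 nM, which leaves compound 1 level with compound 2, within the usual scatter of such measurements. These two compounds do not differ in just one place, so the data show no measured effect of a single structural change. Compound 3 `COc1ccc(CN2C(=O)C(=O)c3cc(/C=C/C(=O)OC(C)(C)C)ccc32)cc1` is still to be measured. It departs from compound 1 in one place, with tert-butyl in place of ethyl on an oxygen next to a carbonyl group. For the measured compounds named here, with no measured step to guide the expectation, no step beyond the scatter is expected in this assay, and the estimated step, a 1.2-fold higher number from compound 1 to compound 3 (0.09 log units; within the scatter), leans only slightly towards weaker inhibition. This expectation starts from compound 1 at 90 nM. For compound 3 the estimated value is 110 nM, with an expected range of 40 nM to 320 nM.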

Compound 3, half-maximal inhibitory concentration: 620 nM
Compound 3: the middle estimate sits 5.6-fold (0.75 log units) below what was measured, outside the stated range (above it).
By their numbers in this assay, from the lowest: compounds 1 and 2 (each within the scatter of the next); then compound 3.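

In this assay, tert-butyl in place of ethyl on an oxygen next to a carbonyl group gives a 6.9-fold higher number from compound 1 to compound 3 (0.84 log units; beyond the scatter), towards weaker inhibition, so this position does not tolerate every group it is given, as the comparison of compound 1 with compound 2 could not reveal because they differ in more than one place. The step comes with only a change from 2 to 4 heavy atoms, all carbon, and with no change in ring count, hydrogen-bond donors, hydrogen-bond acceptors or net charge. The data at hand give no measured explanation for this step.

From the compounds shown here alone, it remains open whether isopropyl or a longer chain such as n-butyl on that oxygen would stay level with ethyl or follow tert-butyl, and what a carboxylic acid there would do. Going by these compounds, it is also open whether the same change would give a similar step on the core of compound 2, with its different group on the ring nitrogen.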